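The source may report more compounds than this note shows. Statements on the series, on what has been measured and on what is new or still open speak of the compounds shown alone.

Three compounds share one core and were tested in a functional assay on A-375 cells (Homo sapiens) for antiproliferative activity, read by trypan blue exclusion, with a stated time of 48 h, tested at 1 uM; on this read-out lower numbers stand for a stronger effect and higher numbers for a weaker effect at the one concentration tested. Compound 1, `CCCCC#Cc1ccc(S(=O)(=O)Nc2cccc(-c3csc(NC(C)=O)n3)c2)cc1`, gives 73.2%, the highest of the three numbers. Compound 2, `CCCCCCC#Cc1cccc(S(=O)(=O)Nc2cccc(-c3csc(NC(C)=O)n3)c2)c1`, gives 56.9%, and compound 3, `CC(=O)Nc1nc(-c2cccc(NS(=O)(=O)c3cccc(C#C[Si](C)(C)C)c3)c2)cs1`, gives 61.6%. Among the compounds with values here, the only step between compounds differing in one place is a number 4.7 percentage points higher from compound 2 to compound 3 (within the scatter), which changes a chain on a triple-bonded carbon and does not reach beyond the scatter.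

Compound 4, `CCCCCC/C=C\c1ccc(S(=O)(=O)Nc2cccc(-c3csc(NC(C)=O)n3)c2)cc1`, is not yet measured. It differs from compound 1 by a group of 8 heavy atoms (8 carbon; no ring) in place of a group of 6 heavy atoms (6 carbon; no ring), on an aromatic carbon, the newcomer being a chain with one double bond outside aromatic rings, sitting on an aromatic carbon of a six-membered aromatic ring of carbon only, para to a large group.

Within the data shown here, no measured step changes a chain in this way at this place, so the expectation rests on the one chain-swap step, which was within the scatter. For compound 4 the expected step is a number 4.2 percentage points lower from compound 1 to compound 4 (within the scatter), none beyond the scatter. Compound 4 is therefore estimated at 69%, within 52% to 86%.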

Compound 4, a percentage reported as activity, at one concentration (the size of the read-out at that concentration, not a potency): 48.8%
Compound 4: middle estimate off by 20.2 percentage points, on the high side, and the stated range ends above it.
By their numbers in this assay, from the lowest: compounds 4, 2 and 3 (each within the scatter of the next, the first and the last beyond it); then compound 1.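

In this assay, replacing the hex-1-yn-1-yl chain with a chain of 8 carbons holding one double bond, on an aromatic carbon para to a large group, gives a number 24.4 percentage points lower from compound 1 to compound 4 (beyond the scatter). Unlike the earlier chain swap on a triple-bonded carbon, which stayed within the scatter, this change at the aromatic carbon goes beyond it, so the read-out at the one concentration tested does respond to the chain here. Chain length and bond type change together in this single step, and nothing measured here explains the difference.

The compounds shown leave open whether the extra length or the double bond carries the step. An oct-1-yn-1-yl chain or a hex-1-en-1-yl chain at this place would pull the two apart, and a fully saturated octyl chain would show whether any multiple bond is needed at all.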